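The source may report more compounds than this note shows. Statements on the series, on what has been measured and on what is new or still open speak of the compounds shown alone.

Of the compounds shown here, three have been measured in an assay on cells for inhibition of cytochrome P450 11B2, mitochondrial (Homo sapiens), read by HTRF; on this read-out higher numbers stand for weaker inhibition and lower numbers for stronger inhibition. Compound 1 `CC1(C)c2cc(Cl)ccc2C(=O)N1c1cncc(N2CCN(S(C)(=O)=O)CC2)c1` gives 2 nM, compound 2 `CC(=O)N1CCN(c2cncc(N3C(=O)c4ccc(Cl)cc4C3(C)C)c2)CC1` gives 9 nM, and compound 3 `N#Cc1ccc2c(c1)CN(c1cccnc1)C2=O` gives 232 nM. Compound 2 therefore stands second highest of the three, much nearer to compound 1 than to compound 3. Going by the values given here, the only step between two compounds that differ in one place is a 4.5-fold higher number from compound 1 to compound 2 (0.65 log units; beyond the scatter). Compound 4 `CC(=O)N1CC[C@H](Oc2cncc(N3C(=O)c4ccc(Cl)cc4C3(C)C)c2)C1` differs from compound 2 by a group of 9 heavy atoms (6 carbon, 1 nitrogen, 2 oxygen; one five-membered non-aromatic ring with 1 hetero atom) in place of a group of 9 heavy atoms (6 carbon, 2 nitrogen, 1 oxygen; one six-membered non-aromatic ring with 2 hetero atoms), on an aromatic carbon. Among the compounds with values here, no measured step swaps one whole ring group for another in this way, so the acetyl step gives only a rough sense of how far the number may move; a change of similar modest size is expected, more likely upward than downward. Compound 4 is expected to give 20 nM, within a range from 5 nM to 80 nM. That estimate corresponds to a step of a 2.2-fold higher number from compound 2 to compound 4 (0.35 log units; beyond the scatter).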

Compound 4, half-maximal inhibitory concentration: 7 nM
Estimate against measurement, compound 4: 2.9-fold (0.46 log units) above; measured number inside the range.
By their numbers in this assay, from the lowest: compound 1; then compounds 4 and 2 (each within the scatter of the next); then compound 3.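

At this aromatic carbon, the whole 4-acetylpiperazin-1-yl group can be exchanged for a five-membered non-aromatic ring group with one defined stereocentre, and the result in this assay is a 1.3-fold lower number from compound 2 to compound 4 (0.11 log units; within the scatter). So the two ring groups cannot be told apart here, which the acetyl step alone could not show. No measured evidence explains this.

Still open, on these data alone, is whether methylsulfonyl in place of the acetyl on compound 4 would move the number as it does between compound 2 and compound 1. The opposite stereocentre, or a free amine on that ring, also remains untested in the compounds shown.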